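The source may report more compounds than this note shows. Statements on the series, on what has been measured and on what is new or still open speak of the compounds shown alone.

Measured so far in a functional assay on HepG2 cells (Homo sapiens) for cytotoxicity, read by MTT assay, with a stated time of 48 h (on this read-out lower numbers stand for stronger inhibition and higher numbers for weaker inhibition), are two compounds.
Compound 1 `CC1=NN(C(=O)CCc2ccccc2)C(c2cc(Br)ccc2O)C1` gives 17900 nM as its value
Compound 2 `CC1=NN(C(=O)COc2ccc(Cl)cc2)C(c2cc(Br)ccc2O)C1` gives "not active" (no number reported) as its result

Compound 2 was reported only as "not active" (no number reported) and has no single number, so it cannot be placed on a scale beside compound 1 and its 17900 nM figure. Compound 3 `CC1=NN(C(=O)COc2ccc(Cl)cc2)C(c2cc(Br)cc(Br)c2O)C1` has not yet been measured. The change bromo in place of hydrogen on an aromatic carbon is bromo in place of hydrogen on an aromatic carbon, ortho to a hydroxy group. For the measured compounds named here, no measured pair shows what such a swap does, so any forecast is loose. A modest step towards stronger inhibition in this assay is expected, at best reaching a weak but measurable number, and compound 3 could equally end up without a number. Compound 3 is estimated at 25000 nM with a range from 6000 nM to 90000 nM expected.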

Compound 3, half-maximal inhibitory concentration: "not active" (no number reported)
For compound 3 the study gives words and no number, and the estimate cannot be compared.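

In this assay compound 2 and compound 3 are both reported only in words, as not active, so no step can be read for the added bromo. No evidence available bears on this result. From the compounds shown here alone, what the bromo does to the strength of inhibition stays open.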